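Aminothiophene ketones: aryl addition next to the ring sulfur

This account rests on a few compounds, and the source may have more. Where it says the series, first, only, none or still open, it means among the compounds named here.

compound 1 `CC(C)(C)Cc1csc(N)c1C(=O)c1ccc(Cl)cc1` 5%
compound 2 `CC(C)(C)Cc1csc(N)c1C(=O)c1cccc(Cl)c1` 8%

Two compounds of the shared core have been run in an assay on CHO cells for displacement of a labelled ligand from adenosine receptor A3 (Homo sapiens), read by scintillation counting, tested at 10 uM; a higher number here means more inhibition at the concentration tested (going by the name of the read-out), a lower number less inhibition. Compound 1 `CC(C)(C)Cc1csc(N)c1C(=O)c1ccc(Cl)cc1` gives 5%; compound 2 `CC(C)(C)Cc1csc(N)c1C(=O)c1cccc(Cl)c1` gives 8%. Compound 1 holds the lower of the two numbers, but the gap to its nearest neighbour, compound 2, lies within the scatter, so the two are read as the same: both show little displacement of the labelled ligand at the concentration tested.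

Compound 3 `Cc1cccc(-c2sc(N)c(C(=O)c3ccc(Cl)cc3)c2CC(C)(C)C)c1` is not yet measured. It differs from compound 1 in one place: 3-methylphenyl in place of hydrogen on an aromatic carbon. Among the measured compounds shown here, no step between two measured compounds is available, so the weight of this change is not known from the series itself. What can be said is that every measured member of this core gives a low number in this assay, and a single addition of a ring would have to lift the read-out a long way to count as more than scatter.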

Compound 3, a percentage reported as inhibition, at one concentration (the size of the read-out at that concentration, not a potency): 1%
The estimate for compound 3 lay 19 percentage points above the measured number, within the range that was stated.
By their numbers in this assay, from the lowest: compounds 3, 1 and 2 (each within the scatter of the next).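

Among the compounds shown here, the first step at this position, a number 4 percentage points lower from compound 1 to compound 3 (within the scatter), was read in this assay. With 3-methylphenyl in place of hydrogen on the aromatic carbon next to the ring sulfur, compound 3 reads the same as compound 1, so an added aromatic ring of 7 heavy atoms at this carbon does not take the series out of the low range seen for compounds 1 and 2. No supporting data bear on why this addition leaves the reading unmoved.

Still open, going by these compounds, is whether this carbon responds to a group of another kind, such as a carboxylic acid, an aminomethyl group or a morpholine ring, or to a shorter substituent such as a methyl group, since a single aryl group gives no trend for the position. Also open, on these data alone, is whether 3-methylphenyl at the same carbon reads the same on the core of compound 2, and the single-concentration read-out cannot separate compounds whose numbers all lie this low.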